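Amino for Chloro on the Core of Compound 2

The compounds below may be only part of what the source reports. "The series", "measured", "known", "first", "only" and "open" are said of these compounds alone.

Measured compounds:
- Compound 1, `Nc1nn(C(=O)Nc2ccc(Cc3ccccc3)cc2)c2ccccc12`: 35900 nM
- Compound 2, `Nc1nn(C(=O)Nc2ccc(Cc3ccccc3)cc2)c2ccc(Cl)cc12`: 1530 nM

Within the data shown here, in a functional assay on HCC 2998 cells (Homo sapiens) for antiproliferative activity, read by sulforhodamine B assay, with a stated time of 48 h (a lower number here means a stronger inhibitor of growth, a higher number a weaker inhibitor of growth), compound 2 gives the lowest of the two numbers; its only neighbour is compound 1, and the step of a 23-fold lower number from compound 1 to compound 2 (1.37 log units; beyond the scatter) separates them. Compound 3, `Nc1ccc2c(c1)c(N)nn2C(=O)Nc1ccc(Cc2ccccc2)cc1`, is not yet measured. It differs from compound 2 by amino in place of chloro on an aromatic carbon. Among the measured compounds shown here, the only measured step that bears on this position is the one from hydrogen to chloro, which was large and favourable; no step tells what happens when amino replaces chloro there. Since the gain of compound 2 rests on a chloro that compound 3 no longer carries, a move back toward compound 1 is expected, though an amino is not a hydrogen, so compound 3 is estimated at 10000 nM, with a range of 2000 nM to 50000 nM, a step of a 6.5-fold higher number from compound 2 to compound 3 (0.82 log units; beyond the scatter) in this assay.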

Compound 3, concentration for total growth inhibition: 14800 nM
The estimate for compound 3 lay 1.5-fold (0.17 log units) below the measured number; the measured number falls inside the stated range.
By their numbers in this assay, from the lowest: compound 2; then compound 3; then compound 1.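

In this assay, this aromatic carbon now carries three different groups, and the outcome is graded rather than all or nothing. Amino gives up much of what chloro gained (a 9.7-fold higher number from compound 2 to compound 3 (0.99 log units; beyond the scatter)), yet it still keeps a smaller gain over hydrogen (a 2.4-fold lower number from compound 1 to compound 3 (0.38 log units; beyond the scatter)), so the improvement over hydrogen is not unique to chloro among the groups shown. Chloro and amino each count one heavy atom, so that count does not separate them, and nothing available accounts for the order of chloro, amino and hydrogen.

As far as these compounds go, it remains open where a fluoro, a bromo, a methoxy or a carboxylic acid on this carbon would fall in that order. From the compounds shown here alone, it is also open whether the same order would hold on a different substitution of the shared core.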